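Bromo in place of hydrogen: from compound 2 to compound 4

The compounds below may be only part of what the source reports. "The series", "measured", "known", "first", "only" and "open" are said of these compounds alone.

Working notes on the series. In a functional assay on A549 cells (Homo sapiens) for cytotoxicity (on this read-out higher numbers stand for weaker inhibition and lower numbers for stronger inhibition), compound 1 `COc1ccc2c(-c3cc(C(F)(F)F)c(C#N)c(-c4cn(S(=O)(=O)c5ccc(C)cc5)c5cc(OC)ccc45)n3)cn(S(=O)(=O)c3ccc(C)cc3)c2c1` gives only a limit, > 100000 nM. Compound 3 `COc1ccc2c(c1)c(-c1cc(C(F)(F)F)cc(-c3cn(S(=O)(=O)c4ccc(C)cc4)c4ccc(OC)cc34)n1)cn2S(=O)(=O)c1ccc(C)cc1` likewise gives only a limit in this assay, > 100000 nM. Within the data shown here, compound 2 `Cc1ccc(S(=O)(=O)n2cc(-c3cc(C(F)(F)F)ccn3)c3ccccc32)cc1` is the single member with a number on this read-out: in this assay compound 2 gives 25000 nM. Compound 2 therefore stands apart from the other two values, which sit at the limit of > 100000 nM in this assay, at which 2 of the 3 values shown sit, and no ordering beyond that can be read from them.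

Compound 4 `Cc1ccc(S(=O)(=O)n2cc(-c3cc(C(F)(F)F)ccn3)c3cc(Br)ccc32)cc1` has not yet been measured. It differs from compound 2 by bromo in place of hydrogen on an aromatic carbon. Among the measured compounds shown here, no pair of measured compounds in this set differs in a single place, so no measured step is available to scale this change. With the shared core of compound 2 retained and only one heavy atom entering, the step from compound 2 to compound 4 in this assay is expected to stay within or close to the usual scatter, with no clear direction. Compound 4 is estimated at 18000 nM, in the range 6000 nM to 60000 nM, which corresponds to an expected step of a 1.4-fold lower number from compound 2 to compound 4 (0.14 log units; within the scatter).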

Compound 4, half-maximal inhibitory concentration: 4100 nM
For compound 4 the middle estimate is 4.4-fold (0.64 log units) above the measured one; measured number below the stated range.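

In this assay, among these compounds, the change gives a 6.1-fold lower number from compound 2 to compound 4 (0.79 log units; beyond the scatter), the first step between two measured compounds that differ in one place. It shows that this aromatic carbon, meta to a fused ring and para to a fused ring, is not a silent position: a single heavy atom, bromo in place of hydrogen, moves the read-out towards stronger inhibition. The data shown assign no cause to this step.

On these data alone, whether chloro, an amine or a carboxylic acid on the same carbon would shift the number in the same direction, or by a similar amount, stays open. Compound 1 and compound 3 differ from this pair in more than one place, and their values offer no scale for the step: the limit of > 100000 nM in this assay, at which 2 of the 4 values shown sit.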